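Glycolamide anilide in place of pyrrolidine on a fused core

A few compounds are considered here, and "the series" means these few. Any claim that something is new, unique, unknown or untested is made for them only; others in the source may bear on it.

Measured compounds:
compound 1 `CN1CCN(c2ccc(Nc3ncc4nc(Nc5ccc(F)cc5)n([C@H]5CCN(C(=O)CO)C5)c4n3)cc2)CC1` gives "not determined" (no result reported)
compound 2 `CN1CCN(c2ccc(Nc3ncc4nc(Nc5ccccc5)n([C@@H]5CCN(S(=O)(=O)C6CC6)C5)c4n3)cc2)CC1` gives 200 nM

Compound 1 stands without a number: in a functional assay on NCI-H1975 cells (Homo sapiens) for antiproliferative activity, read by MTT assay, with a stated time of 72 h (a lower number here means a stronger inhibitor, a higher number a weaker inhibitor), compound 1 is recorded as "not determined" (no result reported), so it gives no anchor of its own. Compound 2, which shares the core and the methylpiperazinylphenylamino group but carries a cyclopropylsulfonyl pyrrolidine and a plain phenylamino, is the only measured point; in this assay compound 2 gives 200 nM.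

Compound 3 `CN1CCN(c2ccc(Nc3ncc4nc(Nc5ccc(F)cc5)n(-c5cccc(NC(=O)CO)c5)c4n3)cc2)CC1` is the unmeasured analogue. It differs from compound 1 in one place: 3-(((hydroxymethyl)carbonyl)amino)phenyl in place of 1-((hydroxymethyl)carbonyl)pyrrolidin-3-yl on an aromatic nitrogen

Among the compounds with values here, no measured pair describes this change, so the size of the step in this assay cannot be read from data; a modest shift in either direction, possibly within the scatter, is expected. Taking compound 2 as the nearest reference, compound 3 is expected to give about 150 nM, with a range from 40 nM to 600 nM.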

Compound 3, half-maximal inhibitory concentration: 580 nM
Estimate against measurement, compound 3: 3.9-fold (0.59 log units) below; the range from low to high includes it.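

In this assay, within the data shown here, compound 1 is recorded as "not determined" (no result reported) while compound 3 gives 580 nM so no step between them can be read. The compounds shown leave open how swapping the group on the aromatic nitrogen changes activity, and no evidence shown bears on this result.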